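Aromatic and halogen substituents on a shared nucleoside core

The source may report more compounds than this note shows. Statements on the series, on what has been measured and on what is new or still open speak of the compounds shown alone.

Measured so far in a functional assay on CCRF-CEM cells (Homo sapiens), read by MTT assay, with a stated time of 72 h; a higher number here means a weaker inhibitor, a lower number a stronger inhibitor:
compound 1, `COc1ncnc2c1c(-c1ccoc1)cn2[C@@H]1O[C@H](CO)[C@@H](O)[C@H]1O`, gives 110 nM.
compound 2, `C#Cc1cn([C@@H]2O[C@H](CO)[C@@H](O)[C@H]2O)c2ncnc(OC)c12`, gives only a limit of the assay, > 20000 nM.
compound 3, `COc1ncnc2c1c(I)cn2[C@@H]1O[C@H](CO)[C@@H](O)[C@H]1O`, gives 1150 nM.

Compound 3 stands at the highest of the two numbers shown; the nearest is compound 1, with a 10-fold higher number from compound 1 to compound 3 (1.02 log units; beyond the scatter). Compound 2 is known only as a limit, (the limit of > 20000 nM in this assay, at which 1 of the 3 values shown sits), so its distance from compound 3 is read as an at least 17-fold lower number from compound 2 to compound 3 (1.24 log units; beyond the scatter).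

Compound 4, `COc1ncnc2c1c(-c1cc3ccccc3o1)cn2[C@@H]1O[C@H](CO)[C@@H](O)[C@H]1O`, differs from compound 3 in one place: 1-benzofuran-2-yl in place of iodo on an aromatic carbon.

For the measured compounds named here, two measured steps bear on this change. The step of a 10-fold higher number from compound 1 to compound 3 (1.02 log units; beyond the scatter) shows that iodo on this aromatic carbon gives a clearly higher number than furan-3-yl, so returning an aromatic ring to that carbon is expected to move the number back down. The step of an at least 17-fold lower number from compound 2 to compound 3 (1.24 log units; beyond the scatter) shows that not every small group at this position is tolerated, which points to the ring itself as what matters. No compound with 1-benzofuran-2-yl is shown, so the step is expected to be large and downward, a 3.8-fold lower number from compound 3 to compound 4 (0.58 log units; beyond the scatter), though not necessarily reaching compound 1.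

Compound 4 is therefore expected to give about 300 nM in this assay, within 60 nM to 3000 nM.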

Compound 4, half-maximal inhibitory concentration: 5370 nM
For compound 4 the middle estimate is 18-fold (1.25 log units) below the measured one; the whole stated range lies below it.
By their numbers in this assay, from the lowest: compound 1; then compound 3; then compound 4. At a limit, above all of these: compound 2.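

In this assay, an aromatic ring on this carbon does not by itself give a lower number: with a 4.7-fold higher number from compound 3 to compound 4 (0.67 log units; beyond the scatter), 1-benzofuran-2-yl ranks behind the single iodine atom it replaces. The comparison between the two ring-bearing compounds is sharper, a 49-fold higher number from compound 1 to compound 4 (1.69 log units; beyond the scatter), so the position distinguishes furan-3-yl from 1-benzofuran-2-yl, although each brings a five-membered aromatic ring with 1 hetero atom. The remaining step, an at least 3.7-fold lower number from compound 2 to compound 4 (0.57 log units; beyond the scatter), gives only a minimum size and direction, as it rests on a limit: the limit of > 20000 nM in this assay, at which 1 of the 4 values shown sits.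

The shift from furan-3-yl to 1-benzofuran-2-yl changes both the attachment point and the ring count, so the compounds shown cannot separate the effect of the added six-membered aromatic ring from that of the attachment point. Furan-2-yl and 1-benzofuran-3-yl would separate these two changes, while phenyl or thiophen-3-yl would show whether the low number of compound 1 extends beyond furan-3-yl.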